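The source may hold more compounds than are shown below. What is called first, only, known or untested is meant among the compounds shown, and "the series" means these compounds.

Measured so far:
Compound 1 `O=C(Cn1c(-c2ccc(Cl)cc2)nc2cccnc21)N1CCCCC1`: 56.2 mg/kg
Compound 2 `C[C@@H](C(=O)N(C)C)n1c(-c2ccc(Cl)cc2)nc2cccnc21`: 31.6 mg/kg

In a functional assay on the whole organism with Mus musculus as the target (on this read-out higher numbers stand for an effect only at larger amounts of compound and lower numbers for an effect already at smaller amounts), compound 2 gives 31.6 mg/kg and compound 1 gives 56.2 mg/kg. These two values lie within the usual scatter of each other, so compound 2 stands level with compound 1.

Compound 3 `CN(C)C(=O)CCn1c(-c2ccc(Cl)cc2)nc2cccnc21` has the same atoms as compound 2, joined differently: 2-(dimethylcarbamoyl)ethyl in place of 1-(dimethylcarbamoyl)ethyl on an aromatic nitrogen. The group on the aromatic nitrogen keeps its name and its counts, but the defined stereocentre of compound 2 is gone.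

No measured step among these compounds shows what such a change does in this assay, so the data offer no direct guide. The expectation rests only on compound 2 at 31.6 mg/kg and compound 1 at 56.2 mg/kg, and no step beyond the scatter is expected, in either direction. The estimate means a 1.3-fold higher number from compound 2 to compound 3 (0.10 log units; within the scatter), an expected step that stays inside the scatter. For compound 3 the estimated value is 40 mg/kg, with an expected range from 15 mg/kg to 100 mg/kg.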

Compound 3, dose for half-maximal effect: 29.4 mg/kg
Compound 3: middle estimate off by 1.4-fold (0.13 log units), on the high side, and the stated range covers the measured number.
By their numbers in this assay, from the lowest: compounds 3, 2 and 1 (each within the scatter of the next).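

Compound 3 shows that, at this position on the aromatic nitrogen, the 2-(dimethylcarbamoyl)ethyl group in place of the 1-(dimethylcarbamoyl)ethyl group gives in this assay a 1.1-fold lower number from compound 2 to compound 3 (0.03 log units; within the scatter), so the defined stereocentre of compound 2 is not required for a value at this level. It also gives the first listed link between the dimethylamide series and the piperidine amide, with a 1.9-fold lower number from compound 1 to compound 3 (0.28 log units; within the scatter), so these three compounds stand level and the different chains and amides on the aromatic nitrogen separate none of them in this assay. No measurement accompanies these numbers that could explain why these changes leave the compounds level.

On these data alone, whether a carboxylic acid or an amine at the end of the chain, or a longer chain such as 4-(dimethylcarbamoyl)butyl, would stay at this level remains open. As far as these compounds go, all three compounds also carry the 4-chlorophenyl group, and what another group there, such as 4-methoxyphenyl, would do is equally open.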